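The source may hold more compounds than are shown below. What is called first, only, known or untested is meant among the compounds shown, and "the series" means these compounds.

In an ADME assay on microsomes from liver (Mus musculus) for metabolic stability, using NADPH, with a stated time of 10 min (on this read-out lower numbers stand for a less stable compound and higher numbers for a more stable compound), compound 1 `CN(C)[C@@H]1CCN(c2cccc3c2C[C@H](CN(C)[C@H]2CCCc4cccnc42)NC3)C1` gives 28.2% and compound 2 `CN1CC[C@H]2CN(c3cccc4c3C[C@H](CN(C)[C@H]3CCCc5cccnc53)NC4)C[C@H]21` gives 24%, so compound 2 stands level with compound 1 within the scatter. Compound 3 `CN1C[C@@H]2CN(c3cccc4c3C[C@H](CN(C)[C@H]3CCCc5cccnc53)NC4)C[C@@H]2C1` changes one group on an aromatic carbon: a group of 9 heavy atoms (7 carbon, 2 nitrogen; 2 five-membered non-aromatic rings with 1 hetero atom each) in place of a group of 9 heavy atoms (7 carbon, 2 nitrogen; 2 five-membered non-aromatic rings with 1 hetero atom each), on an aromatic carbon. The same atoms are simply joined differently. For the measured compounds named here, the only measured step that bears on this, a number 4.2 percentage points lower from compound 1 to compound 2 (within the scatter), also swapped a group on an aromatic carbon, so no change beyond the scatter is expected here. The expected size is a number 2 percentage points higher from compound 2 to compound 3 (within the scatter). For compound 3 the estimate is 26%, with an expected range from 14% to 40%.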

Compound 3, percent of the compound remaining: 32.9%
Compound 3: middle estimate off by 6.9 percentage points, on the low side, and the stated range covers the measured number.
By their numbers in this assay, from the lowest: compounds 2, 1 and 3 (each within the scatter of the next).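

In this assay, joining the same atoms differently gives a number 8.9 percentage points higher from compound 2 to compound 3 (within the scatter) and exchanging the single-ring group for the two-ring group gives a number 4.7 percentage points higher from compound 1 to compound 3 (within the scatter) on this aromatic carbon, so all three groups stand level. Even the largest step seen so far at this position does not pass the scatter, and neither ring arrangement separates from the other. Going by these compounds, whether a different group here, such as a morpholine ring or a carboxylic acid, would shift the number beyond the scatter stays open. No supporting measurement is available to explain these numbers.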